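Amide series: cytotoxicity limits and a fourth analogue

This account rests on a few compounds, and the source may have more. Where it says the series, first, only, none or still open, it means among the compounds named here.

Compound 1 `C=CC1=C(C(=O)Nc2ccccc2OC)C(c2ccc(F)cc2)OC1` is the reference point of the set. In a functional assay on A549 cells (Homo sapiens) for cytotoxicity, read by MTT assay, with a stated time of 24 h (a higher number here means a weaker inhibitor, a lower number a stronger inhibitor), compound 1 gives only the assay limit > 100000 nM and no number. Compound 2 `C=CC1=C(C(=O)Nc2ccc(C)cc2)C(c2ccc(F)cc2)OC1` differs from compound 1 by 4-methylphenyl in place of 2-methoxyphenyl on an amide-type nitrogen. In this assay compound 2 likewise gives only the limit > 100000 nM. Compound 3 `C=CC1=C(C(=O)Nc2ccccc2OC)C(c2ccc(OC)cc2)OC1` differs from compound 1 by methoxy in place of fluoro on an aromatic carbon. In this assay compound 3 also stops at the limit > 100000 nM.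

Neither step can be sized: a step that the two limits leave unreadable from compound 1 to compound 2 and a step that the two limits leave unreadable from compound 1 to compound 3 are both unreadable, because the limit of > 100000 nM in this assay, at which 3 of the 3 values shown sit, leaves no numbers to compare. Nothing in the set yet separates the two amide substituents or the two para groups on the other aromatic ring.

Compound 4 `C=CC1=C(C(=O)Nc2ccc(C)cc2)C(c2ccc(OC)cc2)OC1` is the remaining corner of this square. It differs from compound 3 by 4-methylphenyl in place of 2-methoxyphenyl on an amide-type nitrogen, the same change, at the same kind of place with the same neighbour, that was made from compound 1 to compound 2. How the two cores differ is given by methoxy in place of fluoro on an aromatic carbon.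

For compound 4 the step that the limit leaves unreadable from compound 3 to compound 4 in this assay is expected to be as unreadable as the earlier one, since compound 1, compound 2 and compound 3 all sit at the limit (the limit of > 100000 nM in this assay, at which 3 of the 3 values shown sit). Compound 4 is therefore estimated at 150000 nM in this assay, with a range from 50000 nM to 500000 nM, and most likely to be reported only as a limit.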

Compound 4, half-maximal inhibitory concentration: > 100000 nM
Compound 4 gave a limit, no number; the forecaster's own chance of this, stated with the estimate: 85%; the middle value is on the limit's open side.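

In this assay compound 4 gives > 100000 nM as a limit, not a number. No step from compound 3 or compound 2 to compound 4 can be read, because the comparison rests on limits alone: the limit of > 100000 nM in this assay, at which 4 of the 4 values shown sit.

Going by these compounds, whether 2-methoxyphenyl and 4-methylphenyl on the amide-type nitrogen, or fluoro and methoxy on the aromatic carbon, differ at all in this assay stays open.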